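Methoxy-series urea hydrazones: hydroxyphenyl in place of chlorofluorophenyl

A few compounds are considered here, and "the series" means these few. Any claim that something is new, unique, unknown or untested is made for them only; others in the source may bear on it.

Measured in a functional assay on MCF7 cells (Homo sapiens) for cytotoxicity, read by MTT assay, with a stated time of 72 h; a higher number here means a weaker inhibitor, a lower number a stronger inhibitor:
- compound 1 `O=C(N/N=C/c1ccc(F)cc1Cl)Nc1cc2c(Nc3ccc(F)c(Cl)c3)ncnc2cc1O[C@H]1CCOC1`: 32200 nM
- compound 2 `CCN(CC)c1ccc(/C=N/NC(=O)Nc2cc3c(Nc4ccc(F)c(Cl)c4)ncnc3cc2O[C@H]2CCOC2)c(O)c1`: 15600 nM
- compound 3 `COc1cc2ncnc(Nc3ccc(F)c(Cl)c3)c2cc1NC(=O)N/N=C/c1ccc(F)cc1Cl`: "not active" (no number reported)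

Compound 3 stands apart from compounds 1 and 2: in this assay compound 3 gives "not active" (no number reported), so it carries no number against which a step can be sized. Compound 4 `COc1cc2ncnc(Nc3ccc(F)c(Cl)c3)c2cc1NC(=O)N/N=C/c1ccc(O)cc1` differs from it only in the hydrazone aryl group: 4-hydroxyphenyl in place of 2-chloro-4-fluorophenyl on a carbon with a double bond to nitrogen. Among the measured compounds shown here, the one measured step that bears on this kind of change is a 2.1-fold lower number from compound 1 to compound 2 (0.31 log units; beyond the scatter), a modest gain on exchanging the same leaving group. On that basis a modest improvement over compound 3 is plausible, but with no number for compound 3 the level remains uncertain and weak. Compound 4 is therefore expected near 40000 nM, with a range of 10000 nM to 120000 nM.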

Compound 4, half-maximal inhibitory concentration: 28600 nM
Beside the measured number, compound 4's estimate is 1.4-fold (0.15 log units) above it, and the stated range covers the measured number.
By their numbers in this assay, from the lowest: compounds 2, 4 and 1 (each within the scatter of the next, the first and the last beyond it).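

Among the compounds shown here, compound 3 carries no number, so no step from it to compound 4 can be read. Still open, on these data alone, is how far 4-hydroxyphenyl in place of 2-chloro-4-fluorophenyl moves the number on this core. No supporting data bear on this result.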